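Trifluoromethyl for fluoro on a shared isoxazole-ester scaffold

The source may hold more compounds than are shown below. What is called first, only, known or untested is meant among the compounds shown, and "the series" means these compounds.

Compound 1, `CCOC(=O)c1cc(-c2cccc(OCc3cccc(C(F)(F)F)c3)c2)on1`, in an ADME assay on Vero cells (Chlorocebus sabaeus) for cytotoxicity, with a stated time of 72 h (on this read-out higher numbers stand for weaker inhibition and lower numbers for stronger inhibition), gives > 128000 nM, a limit of the assay.
Compound 2, `CCOC(=O)c1cc(-c2cccc(OCc3ccccc3F)c2)on1`, in this assay stands at "not determined" (no result reported).
Compound 3, `CCOC(=O)c1cc(-c2cccc(OCc3cccc(F)c3F)c2)on1`, in this assay gives > 128000 nM, a limit of the assay.

Compound 3 therefore has no single number of its own; its result is one of two limits among the three entries, and the third entry carries no value at all. Among the compounds with values here, no step between measured compounds can be drawn from these data.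

Compound 4, `CCOC(=O)c1cc(-c2cccc(OCc3cccc(C(F)(F)F)c3F)c2)on1`, differs from compound 3 by trifluoromethyl in place of fluoro on an aromatic carbon. Nothing in the data gives a reason for a shift in either direction, and since compound 1 and compound 3 both sit at the limit of > 128000 nM in this assay, at which 2 of the 3 values shown sit, the expected step from compound 3 to compound 4 is none beyond the scatter, a number no higher from compound 3 to compound 4 (the limit leaves the size open). Compound 4 is accordingly expected at 128000 nM, with a range from 64000 nM to 256000 nM, most likely reported again as a limit.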

Compound 4, half-maximal inhibitory concentration: > 128000 nM
Compound 4: no number, only a limit (the forecaster's own chance of this, stated with the estimate: 85%); the middle value sits exactly at the limit.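

In this assay compound 4 gives only a limit, as do compound 1 and compound 3, and the steps from compound 3 and from compound 1 to compound 4 cannot be read. The compounds shown leave open whether trifluoromethyl in place of fluoro shifts this read-out at all.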